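This account rests on a few compounds, and the source may have more. Where it says the series, first, only, none or still open, it means among the compounds named here.

Of the compounds shown here, two of this set have been tested, and a third awaits testing. Compound 1 `COc1ccc(-c2nnc(N3CCN(C(=O)CN4CCN(c5ccccc5OC)CC4)CC3)nc2-c2ccc(OC)cc2)cc1` carries methoxy groups on its outer rings. In a functional assay on MCF7 cells (Homo sapiens) for cytotoxicity, read by MTT assay, with a stated time of 24 h (on this read-out higher numbers stand for weaker inhibition and lower numbers for stronger inhibition), compound 1 gives > 821000 nM, which is a limit of the assay rather than a measured number. Compound 2 `O=C(CN1CCN(c2ccccc2)CC1)N1CCN(c2nnc(-c3ccc(Cl)cc3)c(-c3ccc(Cl)cc3)n2)CC1` carries chloro groups on the two aryl rings of the shared core and an unsubstituted phenyl on the far piperazine. In this assay compound 2 gives > 850000 nM, again a limit and not a number. Compound 2 therefore stands at the edge of what this assay can report (the limit of > 850000 nM in this assay, at which 1 of the 2 values shown sits), as does compound 1 (the limit of > 821000 nM in this assay, at which 1 of the 2 values shown sits); neither shows measurable cytotoxicity within the tested range.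

Compound 3 `O=C(CN1CCN(c2cccc(Cl)c2)CC1)N1CCN(c2nnc(-c3ccc(Cl)cc3)c(-c3ccc(Cl)cc3)n2)CC1` differs from compound 2 in one place: chloro in place of hydrogen on an aromatic carbon, so that the phenyl becomes a 3-chlorophenyl. Among the compounds with values here, no step between two measured compounds exists here, so nothing calibrates the size of this change. The expected step is a step that the limit leaves unreadable from compound 2 to compound 3, that is, none beyond the usual scatter. Compound 3 is accordingly estimated at 900000 nM, within a range from 300000 nM to 3000000 nM, and the assay will most likely again report only a limit.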

Compound 3, half-maximal inhibitory concentration: > 803000 nM
Compound 3 was reported as a limit; the forecaster's own chance of this, stated with the estimate: 80%; the middle value does not contradict the limit.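

In this assay compound 3 gives > 803000 nM, which is a limit and not a number. Compound 2 gives > 850000 nM, also a limit, so no step can be read between compound 2 and compound 3. The compounds shown leave open whether going from phenyl to 3-chlorophenyl changes cytotoxicity at all.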